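The compounds below may be only part of what the source reports. "The series", "measured", "known", "first", "only" and "open" are said of these compounds alone.

Of the compounds shown here, two with a shared core have been measured so far in a functional assay on A549 cells (Homo sapiens) for antiproliferative activity, read by MTT assay, with a stated time of 48 h; a lower number here means a stronger inhibitor, a higher number a weaker inhibitor. Compound 1 `Fc1ccc2[nH]c(-c3cn(-c4ccccc4)nc3-c3ccccc3)nc2c1`, which carries fluoro, gives 1720 nM. Compound 2 `FC(F)(F)c1ccc2[nH]c(-c3cn(-c4ccccc4)nc3-c3ccccc3)nc2c1`, which carries trifluoromethyl instead, gives 5930 nM, the higher of the two numbers, which makes it the weaker inhibitor of this pair.

The next compound, compound 3 `O=C(OCc1ccccc1)c1ccc2[nH]c(-c3cn(-c4ccccc4)nc3-c3ccccc3)nc2c1`, has benzyloxycarbonyl in place of trifluoromethyl on an aromatic carbon. Within the data shown here, only one measured step bears on this change, a 3.4-fold higher number from compound 1 to compound 2 (0.54 log units; beyond the scatter), a modest one. It shows that swapping the group on this aromatic carbon can move the number, but it is thin guidance here, as neither measured compound carries anything like benzyloxycarbonyl, with its added ring and its carbonyl. No direction can therefore be firmly expected, and a shift of about the measured size either way seems plausible, with a slight lean towards the lower number of compound 1 at 1720 nM. This estimate means an expected 1.5-fold lower number from compound 2 to compound 3 (0.17 log units; within the scatter). For compound 3 the expected value is 4000 nM, with an estimated range from 1200 nM to 14000 nM.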

Compound 3, half-maximal inhibitory concentration: 19300 nM
The estimate for compound 3 lay 4.8-fold (0.68 log units) below the measured number, and the stated range ends below it.
By their numbers in this assay, from the lowest: compound 1; then compound 2; then compound 3.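

In this assay, among these compounds, the aromatic carbon that carries these groups proves able to move the number further than the first pair showed, and in the same direction: benzyloxycarbonyl in place of trifluoromethyl gives a 3.3-fold higher number from compound 2 to compound 3 (0.51 log units; beyond the scatter) and benzyloxycarbonyl in place of fluoro gives an 11-fold higher number from compound 1 to compound 3 (1.05 log units; beyond the scatter) across the series so far. Among these three compounds the number rises in step with the heavy atoms in the group, with benzyloxycarbonyl the largest and the weakest inhibitor, and none of the three goes against this order, although three compounds are too few to establish a trend. Nothing measured here explains why the larger ester-bearing group gives the weaker result.

The compounds shown leave open whether the added benzene ring or the carbonyl accounts for the rise, which a methyl ester or a carboxylic acid on the same carbon would help to separate. They also leave open whether an amine or a plain hydrogen there would give a lower number than the fluoro group of compound 1, or whether fluoro is already close to the best of this series.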